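The source may hold more compounds than are shown below. What is called first, only, known or untested is meant among the compounds shown, and "the series" means these compounds.

In a functional assay on HepG2 cells (Homo sapiens) for inhibition, read by MTT assay, with a stated time of 72 h (on this read-out lower numbers stand for stronger inhibition and higher numbers for weaker inhibition), the two measured compounds share one core. Compound 1 `CCc1ccc(NC(=O)C2CCN(C/C=C/c3ccccc3)CC2)cc1` gives 23300 nM and compound 2 `O=C(Nc1cccc(Cl)c1)C1CCN(C/C=C/c2ccccc2)CC1` gives 20000 nM in this read-out, so compound 2 stands within the scatter of compound 1. Compound 3 `O=C(Nc1ccccn1)C1CCN(C/C=C/c2ccccc2)CC1` differs from compound 2 by the change pyridin-2-yl in place of 3-chlorophenyl on an amide-type nitrogen in which pyridin-2-yl takes the place of 3-chlorophenyl on an amide-type nitrogen. Going by the values given here, from a 1.2-fold lower number from compound 1 to compound 2 (0.07 log units; within the scatter) at the same amide-type nitrogen, the only measured step bearing on this exchange and one within the scatter, no step beyond the scatter is expected in this assay for compound 3, in either direction. Among the compounds with values here, that step involves only groups with an aromatic ring of carbon only, so no measurement yet covers a ring with a hetero atom. The estimated step is a 1.1-fold higher number from compound 2 to compound 3 (0.04 log units; within the scatter) and remains uncertain. For compound 3 the expected value is 22000 nM within an estimated range of 9000 nM to 55000 nM in this read-out.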

Compound 3, half-maximal inhibitory concentration: 51100 nM
Estimate against measurement, compound 3: 2.3-fold (0.37 log units) below; measured number inside the range.
By their numbers in this assay, from the lowest: compounds 2 and 1 (each within the scatter of the next); then compound 3.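

Notes on the amide-type nitrogen in this assay: pyridin-2-yl gives a 2.6-fold higher number from compound 2 to compound 3 (0.41 log units; beyond the scatter) in place of 3-chlorophenyl and a 2.2-fold higher number from compound 1 to compound 3 (0.34 log units; beyond the scatter) in place of 4-ethylphenyl. Going by these compounds alone, these are the first steps beyond the scatter at this position, both modest and both toward weaker inhibition, whereas the exchange between the two groups with an aromatic ring of carbon only stayed within the scatter. So this position does respond to the group it carries, at least when a ring with a hetero atom enters, but no measurement at hand gives a reason for the step.

Still open is whether the ring nitrogen itself or its place in the ring matters, as pyridin-3-yl and pyridin-4-yl are not among the compounds shown. Also open, going by these compounds, is how an aromatic ring of carbon only bearing an amine or a carboxylic acid would behave here.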